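A few compounds are considered here, and "the series" means these few. Any claim that something is new, unique, unknown or untested is made for them only; others in the source may bear on it.

Measured so far in an ADME assay on L02 cells (Homo sapiens) for cytotoxicity, read by MTT assay, with a stated time of 24 h; on this read-out lower numbers stand for stronger inhibition and higher numbers for weaker inhibition:
Compound 1 `O=C1/C(=C/c2cccc(F)c2)CN(S(=O)(=O)c2ccccc2)C/C1=C\c1cccc(F)c1` gives 16200 nM.
Compound 2 `O=C1/C(=C/c2cccc(F)c2)CN(S(=O)(=O)c2ccc(O[N+](=O)[O-])cc2)C/C1=C\c1cccc(F)c1` gives 10700 nM.
Compound 3 `O=C1/C(=C/c2cccc(F)c2)CN(S(=O)(=O)c2ccc(F)cc2)C/C1=C\c1cccc(F)c1` gives 21900 nM.

Compound 3 carries the highest number of the three. Its gap to compound 1 lies within the usual scatter, so the two cannot be told apart on these numbers, while its gap to compound 2 is just beyond it. All three share one core and differ only in the group on the ring attached to the sulfonyl.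

Compound 4 `O=C1/C(=C/c2cccc(F)c2)CN(S(=O)(=O)c2ccc(Br)cc2)C/C1=C\c1cccc(F)c1` continues that series with bromo in place of fluoro on an aromatic carbon. Within the data shown here, no measured pair swaps one halogen for another, so the nearest guides are the two changes already made at this same position: a 1.4-fold higher number from compound 1 to compound 3 (0.13 log units; within the scatter) and a 2.0-fold higher number from compound 2 to compound 3 (0.31 log units; beyond the scatter). Both are small, and one of them does not even clear the scatter. Exchanging one halogen for another at this position is therefore expected to move the number little, if at all, in this assay.

On that basis compound 4 is estimated at 18000 nM, with a range from 9000 nM to 36000 nM. The expected step from compound 3 is a 1.2-fold lower number from compound 3 to compound 4 (0.09 log units; within the scatter), which would stay inside the scatter.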

Compound 4, half-maximal inhibitory concentration: 15800 nM
Compound 4: the middle estimate sits 1.1-fold (0.06 log units) above what was measured; the range from low to high includes it.
By their numbers in this assay, from the lowest: compounds 2, 4, 1 and 3 (each within the scatter of the next, the first and the last beyond it).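

In this assay, this first exchange of one halogen for another at this position, 4-fluorophenyl to 4-bromophenyl, gives a 1.4-fold lower number from compound 3 to compound 4 (0.14 log units; within the scatter) and so leaves the two halogens impossible to tell apart. Bromo also cannot be told apart from the other two groups at this position: hydrogen (a 1.0-fold lower number from compound 1 to compound 4 (0.01 log units; within the scatter)) and nitrooxy (a 1.5-fold higher number from compound 2 to compound 4 (0.17 log units; within the scatter)). Among these compounds, compound 4 is thus the first compound here to lie within the scatter of all the others, and the modest gap between compound 2 and compound 3 remains the only one beyond it, although no information is available to explain why these groups read so alike.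

The compounds shown leave open what an amine, a methoxy group or a carboxylic acid at this same place would give, and whether a longer chain there would move the number clearly beyond the scatter. Everything outside this ring also stays fixed across the four compounds, so the effect of a change elsewhere on the shared core remains unknown.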